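Swapping a Bromine for a Methyl on the Outer Ring

The compounds below may be only part of what the source reports. "The series", "measured", "known", "first", "only" and "open" are said of these compounds alone.

Of the compounds shown here, three built on one shared core have been tested in an assay for inhibition of Polyunsaturated fatty acid 5-lipoxygenase (Homo sapiens), read by spectrophotometry, tested at 10 uM, in the presence of a further agent that is not named here; on this read-out higher numbers stand for more inhibition at the one concentration tested (going by the name of the read-out) and lower numbers for less inhibition. Compound 1 `Cc1nc(NC(=O)c2ccccc2)sc1C(=O)/C=C/c1ccccc1` gives 73.5%. Compound 2 `Cc1nc(NC(=O)c2ccccc2)sc1C(=O)/C=C/c1ccc(Br)cc1` gives 52.3% and stands lowest of the three: compound 1 lies higher by a step beyond the scatter, and compound 3 `COc1ccc(C(=O)Nc2nc(C)c(C(=O)/C=C/c3ccc(F)cc3)s2)cc1`, which gives 88.2%, lies higher still by a step beyond the scatter.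

The compound now in question, compound 4 `Cc1ccc(/C=C/C(=O)c2sc(NC(=O)c3ccccc3)nc2C)cc1`, differs from compound 2 in a single place: methyl in place of bromo on an aromatic carbon. Within the data shown here, only one measured step touches this spot, namely a number 21.2 percentage points lower from compound 1 to compound 2 (beyond the scatter), which shows that putting a bromo there cost a modest amount of inhibition. Among the measured compounds shown here, no measured pair swaps a bromo for a methyl, so the present change cannot be read off directly. Because the step of a number 21.2 percentage points lower from compound 1 to compound 2 (beyond the scatter) was a modest loss on adding the bromo, taking that bromo away and putting in a methyl is expected to recover part of that loss, giving an expected step of a number 12.7 percentage points higher from compound 2 to compound 4 (beyond the scatter). Compound 4 is therefore estimated at 65%, with a range from 45% to 85%.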

Compound 4, a percentage reported as inhibition, at one concentration (the size of the read-out at that concentration, not a potency): 75.1%
The estimate for compound 4 lay 10.1 percentage points below the measured number, within the range that was stated.
By their numbers in this assay, from the lowest: compound 2; then compounds 1 and 4 (each within the scatter of the next); then compound 3.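

In this assay, among these compounds, the change from 4-bromophenyl to 4-methylphenyl gives a number 22.8 percentage points higher from compound 2 to compound 4 (beyond the scatter) and is the only measured step at this spot that raises the number beyond the scatter. Compared with hydrogen at the same carbon, the methyl gives a number 1.6 percentage points higher from compound 1 to compound 4 (within the scatter) and so shows no loss that can be told from the scatter; a group on this carbon therefore does not by itself lower the number, and the loss seen with the bromo is not shared by the methyl. No measurement at hand explains why these two groups, each of one heavy atom, give such different numbers.

As far as these compounds go, with only hydrogen, bromo and methyl compared at this spot, it remains open how an amine, a carboxylic acid or a longer chain such as propyl would behave there. From the compounds shown here alone, compound 3 differs from the other compounds in more than one place, so its standing cannot be assigned to the fluoro on the same ring, and the effect of a fluoro alone on this carbon also remains open.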